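A few compounds are considered here, and "the series" means these few. Any claim that something is new, unique, unknown or untested is made for them only; others in the source may bear on it.

Of the compounds shown here, two from the series have been measured in an assay on CHO-K1 cells for displacement of a labelled ligand from prostaglandin E2 receptor EP1 subtype (Homo sapiens); a lower number here means a stronger inhibitor, a higher number a weaker inhibitor. Compound 1, `Cc1cc(NC(=O)CC2CCCCC2)nn1Cc1cc(Cl)ccc1OCc1ccccc1`, gives 6.31 nM in this assay. Compound 2, `Cc1cc(NC(=O)C2CCOC2)nn1Cc1cc(Cl)ccc1OCc1ccccc1`, gives 39.8 nM in this assay, and it holds the highest of the two numbers; its nearest neighbour is compound 1, and the change a 6.3-fold higher number from compound 1 to compound 2 (0.80 log units; beyond the scatter) is modest but beyond the scatter. Compound 3, `Cc1cc(NC(=O)OCc2ccccn2)nn1Cc1cc(Cl)ccc1OCc1ccccc1`, has not yet been measured; it differs from compound 2 in one place, ((pyridin-2-yl)methoxy in place of oxolan-3-yl on a carbonyl carbon). For the measured compounds named here, only one measured step bears on this position, the step from compound 1 to compound 2, which showed that exchanging one acyl group for another at the carbonyl carbon moves this assay by a modest amount. The new group is larger than the oxolan-3-yl it replaces and adds an aromatic ring, and the carbonyl becomes part of a carbamate rather than an amide, a change the two measured compounds do not cover. Compound 3 is therefore expected to land near 15 nM, within 4 nM to 60 nM, a step of a 2.7-fold lower number from compound 2 to compound 3 (0.42 log units; beyond the scatter) from compound 2.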

Compound 3, half-maximal inhibitory concentration: 79.4 nM
Compound 3: middle estimate off by 5.3-fold (0.72 log units), on the low side; the measured number lies above the stated range.
By their numbers in this assay, from the lowest: compound 1; then compounds 2 and 3 (each within the scatter of the next).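

In this assay the exchange of oxolan-3-yl for (pyridin-2-yl)methoxy on the carbonyl carbon gives a 2.0-fold higher number from compound 2 to compound 3 (0.30 log units; within the scatter) and so does not separate the two compounds, even though the carbonyl now belongs to a carbamate rather than an amide and the group carries an aromatic ring and more heavy atoms. The wider comparison is with cyclohexylmethyl, where the same position shows a 13-fold higher number from compound 1 to compound 3 (1.10 log units; beyond the scatter) in this assay and thus a large step, so that compound 1 stands apart from both compound 2 and compound 3 while these two cannot be ranked against each other. Nothing at hand explains why the two groups read alike or why cyclohexylmethyl differs from them.

The compounds shown leave open whether the distance from compound 1 follows the carbamate link or the group beyond it, which a cyclohexylmethoxy group on the same carbonyl carbon would test directly. They also leave open whether the ring nitrogen matters at all, a question that a benzyloxy group in place of (pyridin-2-yl)methoxy would address.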